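Swapping isopropyl for phenyl on an amide carbonyl

A few compounds are considered here, and "the series" means these few. Any claim that something is new, unique, unknown or untested is made for them only; others in the source may bear on it.

Compound 2 `CC(C)C(=O)Nc1ccc(-c2onc3ccc(C(=O)O)cc23)cc1` has been tested in an assay for inhibition of inositol hexakisphosphate kinase 2 (Homo sapiens), read by colorimetric assay, coupled enzyme assay and malachite green, with a stated time of 120 min, in the presence of a further agent that is not named here (on this read-out lower numbers stand for stronger inhibition and higher numbers for weaker inhibition), where compound 2 gives 820 nM. Among the two numbers in hand this is the higher one, meaning the weaker inhibition. For the measured compounds named here, the only other measured compound, compound 1 `O=C(O)c1ccc2noc(-c3ccc(N4CCCCC4)cc3)c2c1`, gives 240 nM in this assay, and the single measured step, a 3.4-fold higher number from compound 1 to compound 2 (0.53 log units; beyond the scatter), comes from putting (isopropylcarbonyl)amino in place of piperidin-1-yl on an aromatic carbon.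

Compound 3 `O=C(O)c1ccc2noc(-c3ccc(NC(=O)c4ccccc4)cc3)c2c1` is not yet measured. It differs from compound 2 by phenyl in place of isopropyl on a carbonyl carbon, so that the isopropylcarbonyl becomes a benzoyl and the (isopropylcarbonyl)amino becomes a benzamido. Going by the values given here, no measured step touches the carbonyl carbon; the one step known concerns a different place and a different kind of exchange, so it offers no direct guide for this change. With nothing bearing on it, the expectation is that compound 3 gives 700 nM, a step of a 1.2-fold lower number from compound 2 to compound 3 (0.07 log units; within the scatter) that is not expected to pass beyond the usual scatter. The range for compound 3 is estimated as 200 nM to 2500 nM.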

Compound 3, half-maximal inhibitory concentration: 580 nM
Estimate against measurement, compound 3: 1.2-fold (0.08 log units) above; the measured number falls inside the stated range.
By their numbers in this assay, from the lowest: compound 1; then compounds 3 and 2 (each within the scatter of the next).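

In this assay, the carbonyl carbon of the amide accepts a clear change of group with no reading of a gain or a loss: with phenyl in place of isopropyl, the step is a 1.4-fold lower number from compound 2 to compound 3 (0.15 log units; within the scatter) and so gives no sign of a difference between the ring and the branched chain in this pair. The benzamido group also joins the (isopropylcarbonyl)amino group in giving a higher number than piperidin-1-yl, with a 2.4-fold higher number from compound 1 to compound 3 (0.38 log units; beyond the scatter) and thus weaker inhibition that goes beyond the scatter, and neither of the two amides shown goes against this. No measurement at hand gives a reason for either step.

On these data alone, what remains open is how far this tolerance reaches, since two groups on the carbonyl carbon cannot show whether a pyridyl ring, a cyclohexyl ring or a straight butyl chain would behave in the same way. As far as these compounds go, it is also open whether a methoxy or a chloro group on the phenyl could bring the amide series closer to compound 1 240 nM or carry it further away.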